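The source may hold more compounds than are shown below. What is called first, only, known or untested is meant among the compounds shown, and "the series" means these compounds.

Measured so far in a physicochemical assay for lipophilicity, at pH 7.4; a lower number here means a more polar compound, a higher number a more lipophilic compound:
- compound 1 `CCc1ccc(N(CC(C)C)S(=O)(=O)c2ccc3c(c2)C(O)CC(C2CCOCC2)O3)cc1`: 4.12
- compound 2 `CC(C)CN(c1ccccc1F)S(=O)(=O)c1ccc2c(c1)C(O)CC(C1CCOCC1)O2`: 3.39

Compound 1 stands higher of the two. Compound 3 `CCc1ccc(N(CC(C)C)S(=O)(=O)c2ccc3c(c2)C(O)CC(CC2CCOCC2)O3)cc1` has (oxan-4-yl)methyl in place of oxan-4-yl on a saturated ring carbon. Going by the values given here, the only measured step, a number 0.73 log units lower from compound 1 to compound 2 (beyond the scatter), replaces 4-ethylphenyl with 2-fluorophenyl on a sulfonamide nitrogen. It therefore gives a sense of scale but does not involve this position. A small rise in this assay is expected, and the estimated step is a number 0.33 log units higher from compound 1 to compound 3 (beyond the scatter). The estimated value for compound 3 is 4.45, with an expected range of 4.1 to 4.8.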

Compound 3, distribution coefficient: 4.44
Estimate against measurement, compound 3: 0.01 log units above, and the stated range covers the measured number.
By their numbers in this assay, from the lowest: compound 2; then compound 1; then compound 3.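

In this assay, (oxan-4-yl)methyl in place of oxan-4-yl on the saturated ring carbon gives a number 0.32 log units higher from compound 1 to compound 3 (beyond the scatter). Going by these compounds alone, this is the first reading at this position, and it shows a change beyond the scatter although the ring type and the hydrogen-bond donor and acceptor counts of the group stay the same. No available evidence accounts for the step.

On these data alone, it remains open how a longer chain or an amine-bearing group would read at this position. As far as these compounds go, it is also open whether the step would hold with 2-fluorophenyl on the sulfonamide nitrogen.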